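A few compounds are considered here, and "the series" means these few. Any claim that something is new, unique, unknown or untested is made for them only; others in the source may bear on it.

Measured so far in a functional assay on PC-3 cells (Homo sapiens) for cytotoxicity, read by MTT assay, with a stated time of 72 h; a higher number here means a weaker inhibitor, a lower number a stronger inhibitor:
compound 1 `COc1cc(C(=O)c2cc(OC)c(OC)c(OC)c2)cc(NC(=O)/C=C/c2ccc(F)cc2)c1OC` — 4100 nM
compound 2 `COc1cc(C(=O)c2cc(OC)c(OC)c(OC)c2)cc(NC(=O)/C=C/c2ccc(C(F)(F)F)cc2)c1OC` — 4200 nM

In this assay compound 2 gives the higher of the two numbers, with compound 1 as its nearest neighbour, and the two values sit within the scatter of each other. Among the compounds with values here, the single measured step in this assay, a 1.0-fold higher number from compound 1 to compound 2 (0.01 log units; within the scatter), is a trifluoromethyl in place of fluoro on the aromatic ring at the end of the double-bonded chain and moved nothing beyond the scatter.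

Compound 3 `COc1cc(C(=O)c2cc(OC)c(OC)c(OC)c2)cc(NC(=O)/C=C/c2cc(F)c(F)c(F)c2)c1OC` differs from compound 2 by 3,4,5-trifluorophenyl in place of 4-(trifluoromethyl)phenyl on a double-bonded chain carbon bound to a double-bonded chain carbon. Within the data shown here, the only step that bears on this change is the one from compound 1 to compound 2, which altered the fluorine-bearing groups on the same ring and left the number essentially unchanged. On that basis the expected step in this assay is a 1.1-fold lower number from compound 2 to compound 3 (0.02 log units; within the scatter), none beyond the scatter. Compound 3 is therefore estimated at 4000 nM, with a range from 1500 nM to 11000 nM.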

Compound 3, half-maximal inhibitory concentration: 7400 nM
The estimate for compound 3 lay 1.9-fold (0.27 log units) below the measured number; low and high end bracket the measured number.
By their numbers in this assay, from the lowest: compounds 1, 2 and 3 (each within the scatter of the next).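

In this assay, 3,4,5-trifluorophenyl in place of 4-(trifluoromethyl)phenyl gives a 1.8-fold higher number from compound 2 to compound 3 (0.25 log units; within the scatter), and in place of 4-fluorophenyl it gives a 1.8-fold higher number from compound 1 to compound 3 (0.26 log units; within the scatter), with both steps within the scatter. At this place on the double-bonded chain, the assay therefore does not separate the three fluorine-bearing phenyl groups, and this now holds for a ring with three fluorines as well as for the two groups compared earlier. No supporting data are available to explain the size of these steps.

Going by these compounds, all three groups are phenyl rings carrying only fluorine or trifluoromethyl, so it remains open whether an amine, a carboxylic acid or a methoxy group on the ring would give a step beyond the scatter. Also open, on these data alone, is the effect of a longer chain in place of the double-bonded chain.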